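The compounds below may be only part of what the source reports. "The series", "measured", "known", "first", "only" and "open" are said of these compounds alone.

Compound 1 `O=C(CI)NCCCNc1ncnc2c1ncn2[C@@H]1O[C@H](COP(=O)(O)OP(=O)(O)OP(=O)(O)O)[C@@H](O)[C@H]1O` gives 0% in an assay on isolated protein for inhibition of hexokinase-2 (Rattus norvegicus), with a stated time of 6 h, tested at 10 mM; on this read-out higher numbers stand for more inhibition at the one concentration tested (going by the name of the read-out) and lower numbers for less inhibition. Compound 3 `O=C(CI)NCCCCNc1ncnc2c1ncn2[C@@H]1O[C@H](COP(=O)(O)OP(=O)(O)OP(=O)(O)O)[C@@H](O)[C@H]1O` gives 0% in this assay, so compound 1 stands level with compound 3, the pair together the lowest of the three numbers in hand, with no change at the digits printed from compound 1 to compound 3 (within the scatter). Compound 2 `O=C(CI)NCCCCCCCCNc1ncnc2c1ncn2[C@@H]1O[C@H](COP(=O)(O)OP(=O)(O)OP(=O)(O)O)[C@@H](O)[C@H]1O` gives 41% in this assay; the step of a number 41 percentage points higher from compound 1 to compound 2 (beyond the scatter) is the only large movement among the measured compounds, and a number 41 percentage points lower from compound 2 to compound 3 (beyond the scatter) is its mirror. Compound 4 `O=C(CI)NCCCCCC(=O)NCCCNc1ncnc2c1ncn2[C@@H]1O[C@H](COP(=O)(O)OP(=O)(O)OP(=O)(O)O)[C@@H](O)[C@H]1O` differs from compound 1 in one place: 4-(((iodomethyl)carbonyl)amino)butyl in place of iodo on a saturated chain carbon bound to a carbonyl carbon. Among the compounds with values here, no measured step carries this exact change, but the step from compound 1 to compound 2, which also replaces ((iodomethyl)carbonyl)amino with 5-(((iodomethyl)carbonyl)amino)pentyl three bonds along the chain from a nitrogen on an aromatic ring, bears on it most closely. Because a number 41 percentage points higher from compound 1 to compound 2 (beyond the scatter) was large, a rise is expected for compound 4, of about a number 30 percentage points higher from compound 1 to compound 4 (beyond the scatter), though the extra amide in the entering group leaves the size uncertain. Compound 4 is therefore estimated at 30%, expected to lie between 5% and 60%.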

Compound 4, a percentage reported as inhibition, at one concentration (the size of the read-out at that concentration, not a potency): 0%
Compound 4: middle estimate off by 30 percentage points, on the high side; the whole stated range lies above it.
By their numbers in this assay, from the lowest: compounds 1, 3 and 4 (each within the scatter of the next); then compound 2.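

In this assay, placing 4-(((iodomethyl)carbonyl)amino)butyl in place of iodo on a saturated chain carbon bound to a carbonyl carbon gives no change at the digits printed from compound 1 to compound 4 (within the scatter), despite the nine heavy atoms of the entering group. Lengthening at this position therefore does not reproduce what lengthening three bonds along the chain from a nitrogen on an aromatic ring did, where the result was a number 41 percentage points higher from compound 1 to compound 2 (beyond the scatter). The gain seen there does not simply follow from a longer overall chain, as this new change, which also carries an extra amide, shows no such gain. Nothing shown gives a reason for this result. The compounds shown leave open whether a purely saturated carbon chain at this same position, without the amide, would behave as compound 4 does, and whether a still longer chain there would change the reading.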